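Changing the Nitrogen Side Chain of Compound 2

A few compounds are considered here, and "the series" means these few. Any claim that something is new, unique, unknown or untested is made for them only; others in the source may bear on it.

In a functional assay on NCI-H460 cells (Homo sapiens) for inhibition, with a stated time of 72 h (on this read-out higher numbers stand for weaker inhibition and lower numbers for stronger inhibition), compound 1 (`COc1cc(C(=O)c2ccc3c(ccn3C(C)C)c2)cc(OC)c1OC`) gives 1600 nM and compound 2 (`COc1cc(C(=O)c2ccc3c(ccn3CC(=O)O)c2)cc(OC)c1OC`) gives 530 nM, the lower of the two numbers. Compound 3 (`COc1cc(C(=O)c2ccc3c(ccn3CCN(C)C)c2)cc(OC)c1OC`) carries (dimethylamino)methyl in place of carboxy on a saturated chain carbon bound to an aromatic nitrogen. Among the measured compounds shown here, only one measured change involves this chain, a 3.0-fold lower number from compound 1 to compound 2 (0.48 log units; beyond the scatter), a modest step. It shows that the number can shift with this chain, but not which way the new group will move it. A small rise in this assay is expected, a 1.3-fold higher number from compound 2 to compound 3 (0.12 log units; within the scatter). Compound 3 is estimated at 700 nM, with a range of 180 nM to 2500 nM.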

Compound 3, half-maximal inhibitory concentration: 5100 nM
The estimate for compound 3 lay 7.3-fold (0.86 log units) below the measured number, and the stated range ends below it.
By their numbers in this assay, from the lowest: compound 2; then compound 1; then compound 3.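

In this assay, the side chain on the aromatic nitrogen can clearly push the number up as well as down: carboxymethyl to 2-(dimethylamino)ethyl brings a 9.6-fold higher number from compound 2 to compound 3 (0.98 log units; beyond the scatter), and isopropyl to 2-(dimethylamino)ethyl brings a 3.2-fold higher number from compound 1 to compound 3 (0.50 log units; beyond the scatter). Of the three compounds, compound 3 is therefore the weakest, with steps to both others beyond the scatter. No supporting data explain this rise. The compounds shown leave open how an amide, a primary amine or a longer chain ending in a carboxylic acid would behave on this nitrogen.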